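Triazolyl glycoside series: styryl in place of tolyl

The source may hold more compounds than are shown below. What is called first, only, known or untested is meant among the compounds shown, and "the series" means these compounds.

Measured so far:
compound 1 `CC(=O)OC[C@H]1O[C@@H](n2cc(Cn3cc(/C=C/C(=O)c4cccnc4)c4ccccc43)nn2)[C@H](OC(C)=O)[C@@H](OC(C)=O)[C@@H]1OC(C)=O` gives 39800 nM in a functional assay on A549 cells (Homo sapiens) for cytotoxicity, read by sulforhodamine B assay, with a stated time of 48 h; a lower number here means a stronger inhibitor, a higher number a weaker inhibitor
compound 2 `CC(=O)OC[C@H]1O[C@@H](n2cc(CN3C(=O)/C(=C/c4ccc(C)cc4)c4ccccc43)nn2)[C@H](OC(C)=O)[C@@H](OC(C)=O)[C@@H]1OC(C)=O` gives 16000 nM in this assay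
compound 3 `CC(=O)OC[C@H]1O[C@@H](n2cc(CN3C(=O)/C(=C\c4ccc(C)cc4)c4ccccc43)nn2)[C@H](OC(C)=O)[C@@H](OC(C)=O)[C@@H]1OC(C)=O` gives 16500 nM in this assay

Compound 2 holds the lowest of the three numbers in this assay. Its nearest neighbour is compound 3, whose number sits within the scatter, so no order between the two is claimed; the number of compound 1 lies beyond the scatter above that of compound 2.

The next compound is compound 4 `CC(=O)OC[C@H]1O[C@@H](n2cc(CN3C(=O)/C(=C/C=C/c4ccccc4)c4ccccc43)nn2)[C@H](OC(C)=O)[C@@H](OC(C)=O)[C@@H]1OC(C)=O`, made from compound 2 by the change (2-phenylethenyl in place of 4-methylphenyl on a double-bonded chain carbon bound to a double-bonded ring carbon). Among the measured compounds shown here, the only measured step in this set is a 1.0-fold higher number from compound 2 to compound 3 (0.01 log units; within the scatter), which rests on the fact that compounds 2 and 3 differ only in the configuration as drawn and does not touch the aryl group; no measured step changes what hangs on that chain carbon. For the measured compounds named here, the step from compound 2 to compound 4 therefore has no direct precedent, and no move beyond the scatter is expected in this assay. Compound 4 is expected to give 16000 nM, within 5000 nM to 50000 nM. The expected step is no change at the digits printed from compound 2 to compound 4 (within the scatter).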

Compound 4, half-maximal inhibitory concentration: > 100000 nM
Compound 4 was reported as a limit; the forecaster's own chance of this, stated with the estimate: 10%; middle value at least 6.2-fold (0.79 log units) from the limit.
By their numbers in this assay, from the lowest: compounds 2 and 3 (each within the scatter of the next); then compound 1. At a limit, above all of these: compound 4.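

Putting 2-phenylethenyl in place of 4-methylphenyl on a double-bonded chain carbon bound to a double-bonded ring carbon gives an at least 6.2-fold higher number from compound 2 to compound 4 (0.79 log units; beyond the scatter) in this assay, so the reading at this position depends on the group it carries. The earlier pair could not show this, since its step, a 1.0-fold higher number from compound 2 to compound 3 (0.01 log units; within the scatter), lies within the scatter and leaves the aryl group untouched: the fact that compounds 2 and 3 differ only in the configuration as drawn Compound 4 stands at a limit, so the step gives only a minimum size: the limit of > 100000 nM in this assay, at which 1 of the 4 values shown sits.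

The change adds a double bond and removes the methyl in one move, and the compounds shown do not separate the two. Also open, as far as these compounds go, is how a plain phenyl or a 4-aminophenyl on that same carbon would read in this assay.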